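The compounds below may be only part of what the source reports. "The series", "measured", "known", "first", "only" and "open" are said of these compounds alone.

Measured so far in an assay on HEK293 cells for inhibition of P2X purinoceptor 7 (Homo sapiens), read by flow cytometry, with stated times of 15 min and 1 h; a higher number here means a weaker inhibitor, a lower number a stronger inhibitor:
compound 1 `O=C(NCc1ccc(Cl)cc1Cl)[C@@H]1CCC(=O)N1c1cccs1` gives 229 nM
compound 2 `O=C(NCc1ccc(Cl)cc1Cl)[C@@H]1CCC(=O)N1c1ccsc1` gives 813 nM
compound 3 `O=C(NCc1ccc(Cl)cc1Cl)[C@@H]1CCC(=O)N1c1ccoc1` gives 200 nM

Compound 2 has the highest number of the three, and so is the weakest inhibitor shown: a 3.6-fold higher number from compound 1 to compound 2 (0.55 log units; beyond the scatter) and a 4.1-fold lower number from compound 2 to compound 3 (0.61 log units; beyond the scatter) both lie beyond the scatter. Compound 4 `O=C(NCc1ccc(Cl)cc1Cl)[C@@H]1CCC(=O)N1c1cscn1` changes compound 2 in one place: 1,3-thiazol-4-yl in place of thiophen-3-yl on an amide-type nitrogen in a ring. Within the data shown here, the steps that bear on this are the two swaps of the ring on that nitrogen already seen, a 3.6-fold higher number from compound 1 to compound 2 (0.55 log units; beyond the scatter) and a 4.1-fold lower number from compound 2 to compound 3 (0.61 log units; beyond the scatter), each modest; no step with a ring carrying two hetero atoms has been measured. A similar modest move toward a lower number in this assay is therefore expected, with wide uncertainty. Compound 4 is estimated at 450 nM, within 150 nM to 1500 nM, which means an expected 1.8-fold lower number from compound 2 to compound 4 (0.26 log units; within the scatter).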

Compound 4, half-maximal inhibitory concentration: 256 nM
Beside the measured number, compound 4's estimate is 1.8-fold (0.24 log units) above it; low and high end bracket the measured number.
By their numbers in this assay, from the lowest: compounds 3, 1 and 4 (each within the scatter of the next); then compound 2.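

In this assay the 1,3-thiazol-4-yl ring, the first here with two hetero atoms on this amide-type nitrogen, gives a 3.2-fold lower number from compound 2 to compound 4 (0.50 log units; beyond the scatter) and so does not share the high number of thiophen-3-yl. It sits level with the other two rings, with a 1.3-fold higher number from compound 3 to compound 4 (0.11 log units; within the scatter) and a 1.1-fold higher number from compound 1 to compound 4 (0.05 log units; within the scatter) so that, among these four compounds, only thiophen-3-yl stands apart. Nothing measured here gives a reason for this gap. Still open, on these data alone, is how a plain phenyl ring or a pyridin-3-yl ring on this nitrogen would compare.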